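Chalcone series: swapping the aryl group on compound 1

The source may hold more compounds than are shown below. What is called first, only, known or untested is meant among the compounds shown, and "the series" means these compounds.

Compound 1 `CC(C)(C)c1ccc(/C=C/C(=O)c2ccc(OCC(=O)N[C@H]3CCOC3=O)cc2)cc1` was tested in a functional assay on PC-3 cells (Homo sapiens) for antiproliferative activity, read by MTT assay, with a stated time of 72 h (a higher number here means a weaker inhibitor, a lower number a stronger inhibitor), where compound 1 gives 10600 nM. This is the lowest of the three values recorded so far. Compound 2 `O=C1OCC[C@@H]1NC(=S)SCCOc1ccccc1[N+](=O)[O-]` gives 24000 nM in this assay, and compound 3 `O=C1OCC[C@@H]1NC(=S)SCCOc1ccc([N+](=O)[O-])cc1` gives 32500 nM in this assay; both of these lie beyond the scatter above the value of compound 1, so compound 1 stands as the most potent of the three measured compounds. Within the data shown here, compounds 2 and 3 share a dithiocarbamate arrangement rather than the enone of compound 1, and no single-point step links them to it.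

The next compound, compound 4 `O=C(COc1ccc(C(=O)/C=C/c2cccc([N+](=O)[O-])c2)cc1)N[C@H]1CCOC1=O`, keeps the core of compound 1 and changes only one part: 3-nitrophenyl in place of 4-(tert-butyl)phenyl on a double-bonded chain carbon bound to a double-bonded chain carbon. Among the measured compounds shown here, no measured pair shows what this kind of change does in this assay. With nothing to anchor the direction, the step from compound 1 is expected to be small, a 1.1-fold higher number from compound 1 to compound 4 (0.05 log units; within the scatter), likely within the scatter. Compound 4 is therefore estimated at 12000 nM, with a plausible range from 4000 nM to 36000 nM.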

Compound 4, half-maximal inhibitory concentration: 56300 nM
For compound 4 the middle estimate is 4.7-fold (0.67 log units) below the measured one, outside the stated range (above it).
By their numbers in this assay, from the lowest: compound 1; then compounds 2, 3 and 4 (each within the scatter of the next, the first and the last beyond it).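

The first step measured at this position shows that the aryl group on the double-bonded chain carbon is not a neutral site in this assay: 3-nitrophenyl in place of 4-(tert-butyl)phenyl gives a 5.3-fold higher number from compound 1 to compound 4 (0.73 log units; beyond the scatter), toward a weaker inhibitor with the rest of the molecule unchanged. The entering group carries hydrogen-bond acceptors and the leaving group none, but this single pair cannot show which difference between the two groups matters. Nothing available accounts for the loss of potency.

As far as these compounds go, it remains open whether the loss comes from gaining the nitro group or from losing the tert-butyl group, a question that a plain phenyl or a 4-nitrophenyl at this place would address. From the compounds shown here alone, how an amine or a carboxylic acid on this ring would fare also remains open.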